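This account rests on a few compounds, and the source may have more. Where it says the series, first, only, none or still open, it means among the compounds named here.

Compound 1 `Clc1ccccc1CSc1nnc(-c2cnccn2)n1-c1ccccc1`: > 50000 nM (a limit)
Compound 2 `Clc1ccc(CSc2nnc(-c3cnccn3)n2-c2ccccc2)cc1`: > 50000 nM (a limit)
Compound 3 `Fc1cccc(F)c1CSc1nnc(-c2cnccn2)n1-c1ccccc1`: > 50000 nM (a limit)

In a functional assay on HeLa cells (Homo sapiens) for antiproliferative activity, read by MTT assay, with a stated time of 48 h (on this read-out lower numbers stand for stronger inhibition and higher numbers for weaker inhibition), compound 3 gives > 50000 nM, which is a limit and not a number. It has no measured neighbour to be ranked against, for the whole set stands at one value: the limit of > 50000 nM in this assay, at which 3 of the 3 values shown sit.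

The next compound to consider is compound 4 `c1ccc(CSc2nnc(-c3cnccn3)n2-c2ccccc2)cc1`. It carries phenyl in place of 2,6-difluorophenyl on a saturated chain carbon bound to a sulfur. The rest of the molecule stays the same.

For the measured compounds named here, three measured steps bear on this change, since each swaps the group at that same place. They are a step that the two limits leave unreadable from compound 1 to compound 2, a step that the two limits leave unreadable from compound 1 to compound 3 and a step that the two limits leave unreadable from compound 2 to compound 3. None of them has a size that can be read, so they offer no direction to carry over.

The only firm starting point is the limit of compound 3 at > 50000 nM. From it, no step beyond the usual scatter is expected in this assay, and compound 4 may well report only a limit too. The expected change is a step that the limit leaves unreadable from compound 3 to compound 4. For compound 4 the estimated value is 60000 nM, with an expected range from 25000 nM to 120000 nM.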

Compound 4, half-maximal inhibitory concentration: 35600 nM
For compound 4 the middle estimate is 1.7-fold (0.23 log units) above the measured one; the range from low to high includes it.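

In this assay compound 4, which carries a benzyl with no halogen on its ring, is the only compound shown that gives a number rather than a limit, so this position now has a first real value to compare against. Phenyl in place of 2,6-difluorophenyl gives an at least 1.4-fold lower number from compound 3 to compound 4 (0.14 log units; that floor lies within the scatter), and hydrogen in place of chloro on an aromatic carbon gives an at least 1.4-fold lower number from compound 2 to compound 4 (0.14 log units; that floor lies within the scatter) and an at least 1.4-fold lower number from compound 1 to compound 4 (0.14 log units; that floor lies within the scatter). Each of these is only a floor, so the true size of each step may be small or large, and the steps among compound 1, compound 2 and compound 3 cannot be read, which leaves the chloro and fluoro compounds grouped together at one limit: the limit of > 50000 nM in this assay, at which 3 of the 4 values shown sit.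

Whether chloro or fluoro on this ring truly separates compound 1, compound 2 and compound 3 from compound 4 remains unsettled, since no actual gap can be read. Also open, from the compounds shown here alone, is whether a methoxy or an amine on the ring, or a longer chain in place of the benzyl, would move the number in this assay beyond the usual scatter.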